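Cytotoxicity in rat cells: compound 3 to compound 4

The source may report more compounds than this note shows. Statements on the series, on what has been measured and on what is new or still open speak of the compounds shown alone.

Measured compounds:
compound 1 `COc1cc(NC(C)CCCNC(=O)/C(C)=C/c2ccccc2)c2ncccc2c1`, > 100 ug/mL
compound 2 `COc1ccc(/C=C/C(=O)NCCCC(C)Nc2cc(OC)cc3cccnc23)cc1`, > 100 ug/mL
compound 3 `COc1cc(NC(C)CCCNC(=O)/C=C/c2ccc(Cl)cc2)c2ncccc2c1`, 7.1 ug/mL

In an ADME assay on L6 cells (Rattus norvegicus) for cytotoxicity, read by resazurin assay, with a stated time of 70 h (on this read-out lower numbers stand for stronger inhibition and higher numbers for weaker inhibition), compound 1 gives > 100 ug/mL, which is a limit of the assay and not a number. Compound 2 likewise gives > 100 ug/mL, again a limit. Within the data shown here, compound 3 gives 7.1 ug/mL, the only actual number among the three, so it stands as the one compound with measurable cytotoxicity here; the other two sit at the limit of > 100 ug/mL in this assay, at which 2 of the 3 values shown sit. The step of an at least 14-fold lower number from compound 1 to compound 3 (1.14 log units; beyond the scatter) and the step of an at least 14-fold lower number from compound 2 to compound 3 (1.14 log units; beyond the scatter) both point the same way, while a step that the two limits leave unreadable from compound 1 to compound 2 cannot be read because both ends are limits.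

Compound 4 `COc1cc(NC(C)CCCNC(=O)Nc2cccc(O)c2)c2ncccc2c1` differs from compound 3 in one place: (3-hydroxyphenyl)amino in place of 2-(4-chlorophenyl)ethenyl on a carbonyl carbon. The change removes the 2-(4-chlorophenyl)ethenyl group whose arrival produced the large steps from compound 1 and from compound 2, and puts a urea-type substituent in its place. Among the measured compounds shown here, since the chloro-bearing group was the sole feature that separated compound 3 from the limit, its loss is expected to move compound 4 back toward that limit, so a large step upward, an 11-fold higher number from compound 3 to compound 4 (1.05 log units; beyond the scatter), is expected. Compound 4 is therefore estimated at 80 ug/mL, with a range from 25 ug/mL to 100 ug/mL, and the assay may well report only a limit.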

Compound 4, half-maximal inhibitory concentration: 38 ug/mL
For compound 4 the middle estimate is 2.1-fold (0.32 log units) above the measured one, within the range that was stated.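

In this assay, among these compounds, the change on the carbonyl carbon to (3-hydroxyphenyl)amino gives a 5.4-fold higher number from compound 3 to compound 4 (0.73 log units; beyond the scatter), so compound 4 stays on the measurable side of the assay and 2-(4-chlorophenyl)ethenyl is not the only group at this position that yields an actual number. The same group gives an at least 2.6-fold lower number from compound 2 to compound 4 (0.42 log units; beyond the scatter) and an at least 2.6-fold lower number from compound 1 to compound 4 (0.42 log units; beyond the scatter), which shows that, among these compounds, a number can be read at this position without either a chloro group or an ethenyl link. Both of these last two comparisons rest on limits and not on numbers, so they give only a least size for the step: the limit of > 100 ug/mL in this assay, at which 2 of the 4 values shown sit.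

The compounds shown leave open which part of the new group matters, the amino nitrogen that replaces the ethenyl link or the hydroxyl on the aromatic ring, as compound 4 differs from compound 3 in both. Going by these compounds, how a plain phenylamino group or a (4-chlorophenyl)amino group would read at this carbonyl carbon also remains open, and either would separate those two parts.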